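Swapping the fluorine for a methyl on the anilide ring

The compounds below may be only part of what the source reports. "The series", "measured", "known", "first", "only" and "open" are said of these compounds alone.

Among the measured compounds shown here, compound 2 `O=C(O)CCc1ccc(OCc2nnc(C(=O)Nc3cccc(F)c3)s2)cc1` is the stronger of two compounds in a functional assay on CHO cells for agonist activity at Free fatty acid receptor 1 (Homo sapiens), read by calcium flux (on this read-out higher numbers stand for an effect only at larger amounts of compound and lower numbers for an effect already at smaller amounts), where compound 2 gives 1190 nM; the only other number belongs to compound 1 `O=C(O)CCc1ccc(OCc2nnc(C(=O)Nc3ccc(F)cc3)s2)cc1`, which in this assay gives 6640 nM. For the measured compounds named here, the one measured step, a 5.6-fold lower number from compound 1 to compound 2 (0.75 log units; beyond the scatter), is modest. Compound 3 `Cc1ccc(NC(=O)c2nnc(COc3ccc(CCC(=O)O)cc3)s2)cc1` differs from compound 2 by 4-methylphenyl in place of 3-fluorophenyl on an amide-type nitrogen. Going by these compounds, compound 3 again carries a 4-substituted anilide like compound 1, yet the methyl is untested, so only a loose expectation follows: a somewhat higher number, a 2.5-fold higher number from compound 2 to compound 3 (0.40 log units; beyond the scatter). Compound 3 is therefore estimated at 3000 nM, within 1000 nM to 9000 nM.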

Compound 3, half-maximal effective concentration: 4300 nM
Compound 3: middle estimate off by 1.4-fold (0.16 log units), on the low side, within the range that was stated.
By their numbers in this assay, from the lowest: compound 2; then compounds 3 and 1 (each within the scatter of the next).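

Methyl in place of fluoro on an aromatic carbon gives a 1.5-fold lower number from compound 1 to compound 3 (0.19 log units; within the scatter) and so does not separate these two groups in this assay. The other comparison is a 3.6-fold higher number from compound 2 to compound 3 (0.56 log units; beyond the scatter), which shows that the higher number of compound 1 relative to compound 2 is not confined to a fluorine-bearing anilide. No measurement shown gives a reason for this. Going by these compounds, it remains open whether 3-methylphenyl would match compound 2, which would tie the lower number to the ring position rather than to fluorine. On these data alone, how larger groups such as methoxy or trifluoromethyl would behave on this ring also remains open.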